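Same Atoms, Rearranged Side Group

A few compounds are considered here, and "the series" means these few. Any claim that something is new, unique, unknown or untested is made for them only; others in the source may bear on it.

For the measured compounds named here, in an ADME assay on A549 cells (Homo sapiens) for cytotoxicity, read by resazurin assay, with a stated time of 48 h (a lower number here means that less compound is tolerated, a higher number that more compound is tolerated), compound 1 (`CC(=O)Nc1ccc(NC(=O)c2cc(Cl)ccc2O)c(Cl)c1`) has the entry "not determined" (no result reported), so compound 2 (`O=C(Nc1ccc(NCC2CCCC2)cc1Cl)c1cc(Cl)ccc1O`) provides the only number so far, 21500 nM. With nothing to compare it with, that number cannot yet be ranked. Compound 3 (`CC1(Nc2ccc(NC(=O)c3cc(Cl)ccc3O)c(Cl)c2)CCCC1`) holds the same atoms as compound 2, joined differently: 1-methylcyclopentyl in place of cyclopentylmethyl on a nitrogen on an aromatic ring. Going by the values given here, no measured pair shows what such a swap does, so no step beyond the usual scatter is expected in this assay. The expected change is small: a 1.1-fold lower number from compound 2 to compound 3 (0.03 log units; within the scatter). For compound 3 the estimated value is 20000 nM, with an expected range of 8000 nM to 50000 nM.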

Compound 3, half-maximal cytotoxic concentration: 157000 nM
Compound 3: middle estimate off by 7.9-fold (0.89 log units), on the low side; measured number above the stated range.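

In this assay, moving from cyclopentylmethyl to 1-methylcyclopentyl on this nitrogen gives a 7.3-fold higher number from compound 2 to compound 3 (0.86 log units; beyond the scatter). At this position, then, how the same six carbons are joined matters, even with the same atoms and the same five-membered ring. No measurement shown here explains the difference.

From the compounds shown here alone, whether other groups joined in the same way would also raise the number remains open. So does what a cyclohexyl ring or a longer open carbon chain on this nitrogen would give.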